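The compounds below may be only part of what the source reports. "The series", "measured", "known", "first", "only" and "open" are said of these compounds alone.

Measured compounds:
Compound 1 `Cc1nc(S(C)(=O)=O)ccc1Oc1ncnc(OC2CCN(C(=O)OC(C)C)CC2)c1F`: in a functional assay on isolated protein for inhibition of Glucose-dependent insulinotropic receptor (Rattus norvegicus), read by HTRF and cAMP accumulation (a higher number here means a larger maximal response, a lower number a smaller maximal response), compound 1 gives 77%.
Compound 2 `Cc1nc(S(C)(=O)=O)ccc1Oc1ncnc(OC2CCN(C(=O)OC(C)(C)C#N)CC2)c1F`: in this assay compound 2 gives 97%.

Among the measured compounds shown here, compound 2 stands highest of the two numbers; its only neighbour is compound 1, and the one measured step, a number 20 percentage points higher from compound 1 to compound 2 (beyond the scatter), shows the gain that came with the cyano group.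

Compound 3 `Cc1nc(S(C)(=O)=O)ccc1Oc1ncnc(OC2CCN(C(=O)O[C@@H](C)CF)CC2)c1F` differs from compound 2 in one place: 1-(fluoromethyl)ethyl in place of 1-cyano-1-methylethyl on an oxygen next to a carbonyl group. The step from compound 1 to compound 2 is the only one that bears on this change. For the measured compounds named here, compound 3 gives up the cyano group that carried that modest gain, while the 1-(fluoromethyl)ethyl group that enters has no measured precedent here. A modest fall in this assay, back toward the number of compound 1, is therefore expected, as a step of a number 12 percentage points lower from compound 2 to compound 3 (beyond the scatter). Compound 3 is estimated at 85%, with a range from 70% to 100%.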

Compound 3, largest response reached (reported as efficacy), in percent of the reference or control that the assay uses: 84%
Estimate against measurement, compound 3: 1 percentage points above, and the stated range covers the measured number.
By their numbers in this assay, from the lowest: compounds 1 and 3 (each within the scatter of the next); then compound 2.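

In this assay the exchange of 1-cyano-1-methylethyl for 1-(fluoromethyl)ethyl on an oxygen next to a carbonyl group gives a number 13 percentage points lower from compound 2 to compound 3 (beyond the scatter) and thus shows that the higher number of compound 2 does not survive this replacement. Fluoro in place of hydrogen on the saturated chain gives a number 7 percentage points higher from compound 1 to compound 3 (within the scatter) so that, among the three groups shown at this place, only 1-cyano-1-methylethyl stands beyond the scatter of the other two. Nothing on hand explains these differences.

The compounds shown leave open whether the nitrile itself goes with the higher number, which a tert-butyl group at the same place would help to separate from the branching of the chain. They also leave open how the opposite configuration of the defined stereocentre in 1-(fluoromethyl)ethyl would read.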